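A Fluoro to Nitro Step on Compound 2

The source may report more compounds than this note shows. Statements on the series, on what has been measured and on what is new or still open speak of the compounds shown alone.

Compound 1 `O=C(N/N=C/c1ccc(F)cc1)Nc1cc2c(Nc3ccc(F)c(Cl)c3)ncnc2cc1O[C@H]1CCOC1` in a functional assay on HepG2 cells (Homo sapiens) for cytotoxicity, read by MTT assay, with a stated time of 72 h (a higher number here means a weaker inhibitor, a lower number a stronger inhibitor), gives "not active" (no number reported)
Compound 2 `COc1cc2ncnc(Nc3ccc(F)c(Cl)c3)c2cc1NC(=O)N/N=C/c1ccc(F)cc1` in this assay gives 31100 nM

Among the measured compounds shown here, compound 2 (31100 nM) holds the only number in this assay and compound 1 carries none. Compound 3 `COc1cc2ncnc(Nc3ccc(F)c(Cl)c3)c2cc1NC(=O)N/N=C/c1ccc([N+](=O)[O-])cc1` differs from compound 2 in one place. The change is nitro in place of fluoro on an aromatic carbon and reads nitro in place of fluoro on an aromatic carbon, para to a large group. For the measured compounds named here, no measured step shows the effect of such a change, so nothing beyond the scatter is expected in this assay in either direction. The estimated change is small (a 1.2-fold lower number from compound 2 to compound 3 (0.09 log units; within the scatter)). Compound 3 is expected at 25000 nM (estimated range 8000 nM to 70000 nM).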

Compound 3, half-maximal inhibitory concentration: 34100 nM
Compound 3: the middle estimate sits 1.4-fold (0.13 log units) below what was measured; measured number inside the range.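

In this assay, nitro in place of fluoro gives a 1.1-fold higher number from compound 2 to compound 3 (0.04 log units; within the scatter) and so does not separate the two compounds. This first measured step at this position shows that three heavy atoms, with two hydrogen-bond acceptors, can replace a single fluorine without the read-out leaving the scatter. Nothing measured here offers an explanation for this result. As far as these compounds go, whether an amine or a carboxylic acid on this aromatic carbon would shift the number remains open. So does whether any group here can separate a compound from compound 2.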